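This account rests on a few compounds, and the source may have more. Where it says the series, first, only, none or still open, it means among the compounds named here.

Working notes on the series, read in a functional assay on A549 cells (Homo sapiens) for cytotoxicity, read by sulforhodamine B assay, with a stated time of 48 h; a higher number here means a weaker inhibitor, a lower number a stronger inhibitor. Compound 1 `COc1cccc(/C=C/C(=O)c2cccc(-c3cccc(F)c3)c2)c1OC` gives 8900 nM, compound 2 `COc1ccccc1/C=C/C(=O)c1cccc(-c2cccc(F)c2)c1` gives 15500 nM and compound 3 `COc1ccc(/C=C/C(=O)c2ccc(N)c(-c3ccc(F)cc3)c2)cc1OC` gives 8630 nM. Compound 2 differs from each of the other two by no more than the scatter, so these three values set no order.

The next compound is compound 4 `O=C(/C=C/c1ccc(Cl)cc1)c1cccc(-c2cccc(F)c2)c1`, which has 4-chlorophenyl in place of 2-methoxyphenyl on a double-bonded chain carbon bound to a double-bonded chain carbon.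

For the measured compounds named here, only one measured step bears on this change. It is a 1.7-fold higher number from compound 1 to compound 2 (0.24 log units; within the scatter), with hydrogen in place of methoxy on an aromatic carbon of the group that leaves here. That step removes a methoxy group but introduces no chlorine, so it is only an indirect guide. Going by the values given here, compound 3 differs from compound 2 in more than one place and gives no clean step. Among the compounds with values here, no measured compound carries the 4-chlorophenyl group, so the data offer no direct reading of its contribution.

With so little evidence, no shift beyond the scatter is expected in this assay, and no direction is favoured with confidence. The estimated step is a 1.3-fold lower number from compound 2 to compound 4 (0.11 log units; within the scatter). For compound 4 the expected value is 12000 nM, with an estimated range of 5000 nM to 30000 nM.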

Compound 4, half-maximal inhibitory concentration: 15400 nM
Compound 4: middle estimate off by 1.3-fold (0.11 log units), on the low side; the range from low to high includes it.
By their numbers in this assay, from the lowest: compounds 3, 1, 4 and 2 (each within the scatter of the next).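

In this assay, 4-chlorophenyl in place of 2-methoxyphenyl on a double-bonded chain carbon bound to a double-bonded chain carbon gives a 1.0-fold lower number from compound 2 to compound 4 (0.00 log units; within the scatter) and so leaves the reading unchanged within the scatter. For the compounds shown here, all the earlier compounds carry at least one methoxy group on this aromatic ring, so they could not show whether the assay reading survives the loss of every methoxy group together with the arrival of a chlorine. Going by these compounds alone, compound 4 shows that this double exchange at this position produces no readable shift on the core of compound 2, though the single step cannot separate the part played by the departing methoxy group from that of the incoming chlorine, and no measurement on hand accounts for the result.

Open is whether an amine or a carboxylic acid on this phenyl group, or a pyridine ring in its place, would move the number beyond the scatter, since chlorine and methoxy are the only substituents shown here. Also open, going by these compounds, is whether the same exchange would read alike on the core of compound 3, which carries an amine on the other side of the carbonyl.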